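This account rests on a few compounds, and the source may have more. Where it says the series, first, only, none or still open, it means among the compounds named here.

Working notes on the series. Three compounds share one core and differ only in the length of the chain on sulfur: compound 1 `CCCCCCCSC[C@H](NC(C)=O)C(=O)CCl`, compound 2 `CCCCCCCCCCSC[C@H](NC(C)=O)C(=O)CCl` and compound 3 `CCCCCCCCCCCCCCSC[C@H](NC(C)=O)C(=O)CCl`. In a functional assay on MOLT-3 cells (Homo sapiens) (a higher number here means a weaker inhibitor, a lower number a stronger inhibitor), compound 1 gives 2500 nM, compound 2 gives 3400 nM and compound 3 gives 8800 nM. Compound 3 stands highest of the three: the steps of a 3.5-fold higher number from compound 1 to compound 3 (0.55 log units; beyond the scatter) and a 2.6-fold higher number from compound 2 to compound 3 (0.41 log units; beyond the scatter) lie beyond the scatter, whereas a 1.4-fold higher number from compound 1 to compound 2 (0.13 log units; within the scatter) lies within it. Compound 4 `CCCCCCCCCCCCCCCCCCCCCCSC[C@H](NC(C)=O)C(=O)CCl` carries octyl in place of hydrogen on a saturated chain carbon, ten or more bonds along the chain from a sulfur. The two chain extensions that raised the number bear on this step, so a further rise in this assay is expected, estimated as a 3.4-fold higher number from compound 3 to compound 4 (0.53 log units; beyond the scatter). Compound 4 is therefore expected to give about 30000 nM, within 10000 nM to 150000 nM.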

Compound 4, half-maximal inhibitory concentration: > 100000 nM
Compound 4 was reported as a limit; the forecaster's own chance of this, stated with the estimate: 30%; middle value at least 3.3-fold (0.52 log units) away from the limit.
By their numbers in this assay, from the lowest: compounds 1 and 2 (each within the scatter of the next); then compound 3. At a limit, above all of these: compound 4.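

The octyl extension gives the largest step in the series, an at least 11-fold higher number from compound 3 to compound 4 (1.05 log units; beyond the scatter), compared with a 2.6-fold higher number from compound 2 to compound 3 (0.41 log units; beyond the scatter) for the preceding butyl extension. At this position, the rise in the number therefore does not stay modest as the chain grows, and the longest chain reaches the end of the measured range. Compound 4 is reported only as a limit, so its step has a lower bound but no upper one: the limit of > 100000 nM in this assay, at which 1 of the 4 values shown sits.

As far as these compounds go, the true value of compound 4 remains open, as does the course of the rise at chain lengths between those of compound 3 and compound 4. Also open, from the compounds shown here alone, is whether a shorter chain than that of compound 1, or an amine at the chain end, would lower the number.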